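From Dimethoxyphenyl to Nitrophenyl: A Small Expected Step

The source may hold more compounds than are shown below. What is called first, only, known or untested is meant among the compounds shown, and "the series" means these compounds.

In a functional assay on HeLa cells (Homo sapiens) for inhibition, read by MTT assay, with a stated time of 48 h (on this read-out lower numbers stand for stronger inhibition and higher numbers for weaker inhibition), compound 1 `c1ccc(C(c2c[nH]c3ccccc23)c2c[nH]c3ccccc23)cc1` gives 21800 nM, compound 2 `Oc1cccc(C(c2c[nH]c3ccc(Br)cc23)c2c[nH]c3ccc(Br)cc23)c1` gives 3900 nM and compound 3 `COc1ccc(OC)c(C(c2c[nH]c3ccc(Br)cc23)c2c[nH]c3ccc(Br)cc23)c1` gives 5100 nM. Compound 3 therefore sits level with compound 2 within the scatter, and its number is clearly lower than that of compound 1. Compound 4 `O=[N+]([O-])c1ccc(C(c2c[nH]c3ccc(Br)cc23)c2c[nH]c3ccc(Br)cc23)cc1` alters compound 3 at one place, on a saturated chain carbon bound to two aromatic carbons: 4-nitrophenyl in place of 2,5-dimethoxyphenyl on a saturated chain carbon bound to two aromatic carbons. Going by the values given here, only one measured step changes the group at that place: a 1.3-fold higher number from compound 2 to compound 3 (0.12 log units; within the scatter). It stayed within the scatter, but a single step is thin evidence. The expected step in this assay is accordingly none beyond the scatter: a 1.0-fold lower number from compound 3 to compound 4 (0.01 log units; within the scatter). For compound 4 the estimated value is 5000 nM, with an expected range from 2000 nM to 13000 nM.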

Compound 4, half-maximal inhibitory concentration: 1500 nM
The estimate for compound 4 lay 3.3-fold (0.52 log units) above the measured number, and the stated range ends above it.
By their numbers in this assay, from the lowest: compound 4; then compounds 2 and 3 (each within the scatter of the next); then compound 1.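

In this assay the group on this saturated chain carbon can move the number: the earlier change stayed within the scatter, but 4-nitrophenyl gives a 3.4-fold lower number from compound 3 to compound 4 (0.53 log units; beyond the scatter) and also a 2.6-fold lower number from compound 2 to compound 4 (0.41 log units; beyond the scatter) as a step of similar kind. Both steps lie beyond the scatter and are modest in size. Nothing at hand explains why this group gives the lower number. Still open, from the compounds shown here alone, is whether an amine or a carboxylic acid in place of the nitro group would hold this gain, and whether 4-nitrophenyl would do the same on the core of compound 1.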